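Swapping the branched amine arms of compound 3 for straight chains

The source may hold more compounds than are shown below. What is called first, only, known or untested is meant among the compounds shown, and "the series" means these compounds.

In an assay on HEK293 cells for displacement of a labelled ligand from corticotropin-releasing factor receptor 1 (Homo sapiens) (a lower number here means a stronger inhibitor, a higher number a weaker inhibitor), compound 3, `Cc1cc(N(CC(C)C)CC2CC2)c2c(n1)c(-c1ccc(Cl)cc1Cl)nn2C`, gives 3.7 nM. Among the three measured compounds it stands second, with compound 2, `CCCN(CC1CC1)c1cc(C)nc2c(-c3ccc(Cl)cc3Cl)nn(C)c12`, at 1.7 nM closest to it and compound 1, `CCCCNc1cc(C)nc2c(-c3ccc(Cl)cc3Cl)nn(C)c12`, at 170 nM furthest away; the step of a 2.2-fold higher number from compound 2 to compound 3 (0.34 log units; beyond the scatter) is modest and the step of a 46-fold lower number from compound 1 to compound 3 (1.66 log units; beyond the scatter) is large.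

Compound 4, `CCCCCN(CCC)c1cc(C)nc2c(-c3ccc(Cl)cc3Cl)nn(C)c12`, is not yet measured. It differs from compound 3 in one place: pentyl(propyl)amino in place of (cyclopropylmethyl)(isobutyl)amino on an aromatic carbon. Both the leaving and the entering group are amines carrying two alkyl arms, and the three-membered ring is lost.

The steps of a 100-fold lower number from compound 1 to compound 2 (2.00 log units; beyond the scatter) and a 46-fold lower number from compound 1 to compound 3 (1.66 log units; beyond the scatter) show that the large gains came from replacing a single-arm butylamino with a two-arm amine, which compound 4 keeps. The step of a 2.2-fold higher number from compound 2 to compound 3 (0.34 log units; beyond the scatter) shows that changing the shape of one arm moved the number only modestly. For the measured compounds named here, no measured step covers the loss of the three-membered ring itself, so that part is open.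

Compound 4 is therefore expected to stay near compound 3, with the step of a 1.2-fold higher number from compound 3 to compound 4 (0.09 log units; within the scatter), giving an estimated 4.5 nM in this assay, within a range of 1.5 nM to 15 nM.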

Compound 4, inhibition constant: 1.2 nM
Compound 4: middle estimate off by 3.8-fold (0.57 log units), on the high side; measured number below the stated range.
By their numbers in this assay, from the lowest: compounds 4 and 2 (each within the scatter of the next); then compound 3; then compound 1.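

In this assay, for the compounds shown here, the three-membered ring turns out to be dispensable at this position: butyl in place of cyclopropyl leaves the number within the usual scatter (a 1.4-fold lower number from compound 2 to compound 4 (0.15 log units; within the scatter)), a point no earlier step could settle. Two straight arms, pentyl and propyl, also give a lower number than the branched and ring-bearing pair of compound 3 (a 3.1-fold lower number from compound 3 to compound 4 (0.49 log units; beyond the scatter)), although this step is modest and changes both arms at once, so it cannot be divided between them. The large gain from adding a second arm to the amine now appears with an amine that has no ring at all (a 140-fold lower number from compound 1 to compound 4 (2.15 log units; beyond the scatter)), so among these compounds that gain does not depend on the cyclopropylmethyl arm.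

Nothing available here accounts for why these arms give the numbers they do. On these data alone, it also remains open how much length this position accepts, for instance whether a hexyl arm in place of pentyl, or a methoxyethyl arm carrying an ether oxygen in place of propyl, would keep the number in the same range.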